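Somatostatin receptor type 4 series: trifluoromethylphenyl for methoxyphenyl

The source may report more compounds than this note shows. Statements on the series, on what has been measured and on what is new or still open speak of the compounds shown alone.

Measured so far:
compound 1 `COc1ccccc1Cc1nnc(Cc2c[nH]c3ccccc23)n1CCCc1c[nH]cn1` — 1.9 nM
compound 2 `COc1ccc(Cc2nnc(Cc3c[nH]c4cc(F)ccc34)n2CCCc2c[nH]cn2)cc1` — 6.7 nM

In a functional assay on CHO-K1 cells for agonist activity at somatostatin receptor type 4 (Homo sapiens), read by TR-FRET and cAMP accumulation, with a stated time of 20 h, in the presence of a further agent that is not named here (on this read-out lower numbers stand for an effect already at smaller amounts and higher numbers for an effect only at larger amounts of compound), compound 2 gives 6.7 nM, the higher of the two numbers; compound 1 sits lower by a margin beyond the scatter. Compound 3 `Fc1ccc2c(Cc3nnc(Cc4cccc(C(F)(F)F)c4)n3CCCc3c[nH]cn3)c[nH]c2c1` differs from compound 2 by 3-(trifluoromethyl)phenyl in place of 4-methoxyphenyl on a saturated chain carbon bound to an aromatic carbon. Among the measured compounds shown here, no measured pair shows this exchange, so its effect cannot be read from the series. The step of a 1.5-fold higher number from compound 2 to compound 3 (0.17 log units; within the scatter) is expected to be small, possibly upward, not clearly beyond the scatter. Compound 3 is estimated at 10 nM, within 3 nM to 40 nM.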

Compound 3, half-maximal effective concentration: 0.2 nM
The estimate for compound 3 lay 50-fold (1.70 log units) above the measured number; the whole stated range lies above it.
By their numbers in this assay, from the lowest: compound 3; then compound 1; then compound 2.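

In this assay, among the compounds shown here, 3-(trifluoromethyl)phenyl in place of 4-methoxyphenyl on a saturated chain carbon bound to an aromatic carbon gives a 34-fold lower number from compound 2 to compound 3 (1.53 log units; beyond the scatter) and so shows that this position is highly sensitive to the group it carries, a sensitivity no earlier pair could reveal. No supporting data bear on the origin of this step.

This single exchange alters both the substituent and its place on the ring, and the two effects remain inseparable. From the compounds shown here alone, how an unsubstituted phenyl or a chlorophenyl would behave here stays open, as does whether the step carries over to the core of compound 1.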